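A dichloropyridine in place of a pyrazole

The compounds below may be only part of what the source reports. "The series", "measured", "known", "first", "only" and "open" are said of these compounds alone.

Compound 1 `C[C@H](Oc1ccc2ncc(/C=C/C(=O)O)c(C3CC3)c2c1)c1c(Cl)cccc1Cl` gives 3.7 here
Compound 2 `C[C@H](Oc1ccc2ncc(/C=C/C(=O)O)c(C3CC3)c2c1)c1c(Cl)ccc(N)c1Cl` gives 2.8 here
Compound 3 `Cc1cnn(C)c1[C@H](C)Oc1ccc2ncc(/C=C/C(=O)O)c(C3CC3)c2c1` gives 0.9 here

These three compounds were measured in a physicochemical assay for lipophilicity, using the shake flask method (a lower number here means a more polar compound, a higher number a more lipophilic compound), and share one core. Compound 3 stands lowest of them, with compound 2 nearest to it and compound 1 furthest away. Compound 4 `C[C@H](Oc1ccc2ncc(/C=C/C(=O)O)c(C3CC3)c2c1)c1c(Cl)ccnc1Cl` has not yet been measured. It differs from compound 3 at a single place (2,4-dichloropyridin-3-yl in place of 1,4-dimethyl-1H-pyrazol-5-yl on a saturated chain carbon bound to an oxygen on an aromatic ring and a saturated chain carbon), where 2,4-dichloropyridin-3-yl stands in place of 1,4-dimethyl-1H-pyrazol-5-yl.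

The closest measured step is the exchange of 2,6-dichlorophenyl for the same pyrazole, which gave a number 2.80 log units lower from compound 1 to compound 3 (beyond the scatter) and so runs the opposite way. The step of a number 1.90 log units lower from compound 2 to compound 3 (beyond the scatter) also ends at the pyrazole and is large too. A change confined to the dichlorinated ring gave a smaller result, a number 0.90 log units lower from compound 1 to compound 2 (beyond the scatter) in this case. Compound 4 carries a dichlorinated six-membered aromatic ring, as compound 1 with 3.7 does, though its ring holds a hetero atom. A large rise is therefore expected, falling somewhat short of the full distance to compound 1.

The expected change is a number 2.10 log units higher from compound 3 to compound 4 (beyond the scatter) in this assay overall.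

Compound 4 is estimated at 3 with an expected range from 2.5 to 3.5 in this measurement.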

Compound 4, distribution coefficient: 2.3
Estimate against measurement, compound 4: 0.70 log units above, outside the stated range (below it).
By their numbers in this assay, from the lowest: compound 3; then compound 4; then compound 2; then compound 1.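

In this assay, the position on the saturated chain carbon bound to an oxygen on an aromatic ring and a saturated chain carbon now shows that a dichlorinated six-membered aromatic ring does not by itself restore the level of compound 1: the exchange of 1,4-dimethyl-1H-pyrazol-5-yl for 2,4-dichloropyridin-3-yl gave a number 1.40 log units higher from compound 3 to compound 4 (beyond the scatter) and so recovered only part of the distance, while 2,4-dichloropyridin-3-yl in place of 2,6-dichlorophenyl gave a number 1.40 log units lower from compound 1 to compound 4 (beyond the scatter) with a printed size equal to the first. Compound 4 therefore stands midway between the pyrazole and the dichlorophenyl compound, so the single hetero atom in the dichlorinated ring matters as much here as the remaining difference from the pyrazole. The amino-bearing compound also stays above it, with a number 0.50 log units lower from compound 2 to compound 4 (beyond the scatter) as the step, so this ring exchange takes the number lower than the amino group did.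

Nothing measured alongside these numbers accounts for the size of these steps. From the compounds shown here alone, whether an amine on the 2,4-dichloropyridin-3-yl ring would lower the number further stays open, as does the outcome of a methoxy group in place of one of its chlorines.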